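Anilino aryl swap on a purine core with diaminocyclohexane

The source may report more compounds than this note shows. Statements on the series, on what has been measured and on what is new or still open speak of the compounds shown alone.

Measured compounds:
Compound 1 `CC(C)CCn1cnc2c(Nc3ccc(Cl)cc3)nc(N[C@H]3CC[C@H](N)CC3)nc21` gives 10200 nM in a functional assay on HCC827 cells (Homo sapiens) for inhibition, read by fluorescence, with a stated time of 72 h; a higher number here means a weaker inhibitor of growth, a lower number a stronger inhibitor of growth.
Compound 2 `COc1cc(Nc2nc(N[C@H]3CC[C@H](N)CC3)nc3c2ncn3CCC(C)C)cc(OC)c1` gives 11200 nM in this assay.
Compound 3 `CCCCn1cnc2c(Nc3cc(OC)cc(OC)c3)nc(N[C@H]3CC[C@H](N)CC3)nc21` gives 20100 nM in this assay.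

Compound 2 and compound 1 differ by 4-chlorophenyl in place of 3,5-dimethoxyphenyl on a nitrogen on an aromatic ring, and this change gave a 1.1-fold lower number from compound 2 to compound 1 (0.04 log units; within the scatter). The cores of compound 2 and compound 3 differ by hydrogen in place of methyl on a saturated chain carbon bound to two saturated chain carbons, with a step of a 1.8-fold higher number from compound 2 to compound 3 (0.25 log units; within the scatter). Compound 4 `CCCCn1cnc2c(Nc3ccc(Cl)cc3)nc(N[C@H]3CC[C@H](N)CC3)nc21` has not been measured yet. It differs from compound 3 by 4-chlorophenyl in place of 3,5-dimethoxyphenyl on a nitrogen on an aromatic ring, which is the same change as that from compound 2 to compound 1, at the same place. For compound 4 a step of a 1.1-fold lower number from compound 3 to compound 4 (0.05 log units; within the scatter) in this assay is expected because the same change earlier gave a 1.1-fold lower number from compound 2 to compound 1 (0.04 log units; within the scatter). Compound 4 is therefore estimated at 18000 nM, with a likely range from 8000 nM to 40000 nM.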

Compound 4, concentration for 50% growth inhibition: 10800 nM
The estimate for compound 4 lay 1.7-fold (0.22 log units) above the measured number; measured number inside the range.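

The change to 4-chlorophenyl in place of 3,5-dimethoxyphenyl gave a 1.9-fold lower number from compound 3 to compound 4 (0.27 log units; within the scatter) in this assay, and the two readings of this change on different cores do not differ beyond the scatter: the same change on two cores in this assay, a 1.1-fold lower number (0.04 log units; within the scatter) from compound 2 to compound 1 and a 1.9-fold lower number (0.27 log units; within the scatter) from compound 3 to compound 4, 1.7-fold (0.23 log units) apart, within the scatter of two such steps. Hydrogen in place of methyl on the chain gave a 1.1-fold higher number from compound 1 to compound 4 (0.02 log units; within the scatter), and this change also reads alike on both cores: the same change on two cores in this assay, a 1.8-fold higher number (0.25 log units; within the scatter) from compound 2 to compound 3 and a 1.1-fold higher number (0.02 log units; within the scatter) from compound 1 to compound 4, 1.7-fold (0.23 log units) apart, within the scatter of two such steps. Among the compounds shown here, all of these steps lie within the scatter, so the agreement shows only that neither change moved the number beyond it on these cores, not that a step of real size would carry from one core to another.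

The compounds shown leave open whether a phenyl bearing a carboxylic acid on that nitrogen, or a longer chain, would move the number beyond the scatter.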